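Swapping the Aryl Amide Toward a Difluorophenyl Variant

The source may hold more compounds than are shown below. What is called first, only, known or untested is meant among the compounds shown, and "the series" means these compounds.

Of the compounds shown here, two have been measured so far in a functional assay on A549 cells (Homo sapiens) for antiproliferative activity, read by CCK-8 assay, with a stated time of 72 h; on this read-out higher numbers stand for weaker inhibition and lower numbers for stronger inhibition. Compound 1 `Cc1cccc(C(=O)Nc2cccc(-c3oc4cc(-c5ccc(F)cc5)ccc4c(=O)c3O)c2)c1` gives 16500 nM. Compound 2 `O=C(Nc1cccc(-c2oc3cc(-c4ccc(F)cc4)ccc3c(=O)c2O)c1)c1ccc(Br)cc1F` gives 46100 nM, the highest of the two numbers and so the weaker inhibitor. For the measured compounds named here, the only change between them is at the amide: a 2.8-fold higher number from compound 1 to compound 2 (0.45 log units; beyond the scatter).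

Compound 3 `O=C(Nc1cccc(-c2oc3cc(-c4ccc(F)cc4)ccc3c(=O)c2O)c1)c1cc(F)cc(F)c1` has not yet been measured. It differs from compound 2 at the same carbonyl carbon: 3,5-difluorophenyl in place of 4-bromo-2-fluorophenyl on a carbonyl carbon. Both the leaving and the entering group carry no hydrogen-bond donors or acceptors and the same count of heavy atoms, so the change is confined to the pattern of halogens on the aryl ring.

Going by the values given here, only one measured step touches this position, and that step, from compound 1 to compound 2, was modest and beyond the scatter. With a single precedent, its direction for a different halogen pattern cannot be read off. The expected step from compound 2 to compound 3 is therefore a 1.5-fold lower number from compound 2 to compound 3 (0.19 log units; within the scatter), a modest move back toward compound 1, with wide uncertainty. In this assay, compound 3 is estimated at 30000 nM, expected to fall between 12000 nM and 80000 nM.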

Compound 3, half-maximal inhibitory concentration: 7620 nM
Estimate against measurement, compound 3: 3.9-fold (0.60 log units) above; the whole stated range lies above it.
By their numbers in this assay, from the lowest: compound 3; then compound 1; then compound 2.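

For the compounds shown here, the result shows that this position can move the number in either direction: the one earlier step only raised it, whereas this halogen swap gives a 6.0-fold lower number from compound 2 to compound 3 (0.78 log units; beyond the scatter) in this assay. The 3,5-difluorophenyl group also improves on the 3-methylphenyl group, with a 2.2-fold lower number from compound 1 to compound 3 (0.34 log units; beyond the scatter), so the two halogen-bearing rings fall on opposite sides of the methyl-bearing one and the mere presence of halogen does not set the direction of the change. The 4-bromo-2-fluorophenyl and 3,5-difluorophenyl groups have the same count of heavy atoms and no hydrogen-bond donors or acceptors, so those counts do not separate them, and the difference lies in which halogens the ring carries and where they stand.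

No measurement here explains why this change has the effect it does. The compounds shown also leave open how much of the step belongs to losing bromine and how much to rearranging fluorine, since both change at once, and how an aryl ring carrying an amine or a carboxylic acid would behave at this position.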